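Resolving One Stereocentre: From Racemate to Single Enantiomer

The source may report more compounds than this note shows. Statements on the series, on what has been measured and on what is new or still open speak of the compounds shown alone.

Measured so far:
compound 1, `CC1CCc2c(ccc(F)c2Br)N1C=O`: 15.8%
compound 2, `C[C@@H]1CCc2c(ccc(F)c2Br)N1C=O`: "active" (no number reported)

Among the measured compounds shown here, in an assay for inhibition of Rap guanine nucleotide exchange factor 3 (Homo sapiens), read by fluorescence, tested at 10 uM (on this read-out higher numbers stand for a stronger effect at the one concentration tested and lower numbers for a weaker effect), compound 1 gives 15.8%, the only number at hand. Compound 2 is reported merely as "active" (no number reported), with no figure attached. Compound 3, `C[C@H]1CCc2c(ccc(F)c2Br)N1C=O`, keeps every atom and bond of compound 1 and differs in one respect only: the two compounds have the same atoms and bonds; at least one stereo element is drawn with a configuration in one of them and without one in the other: 1 of 1 stereo elements differ; a stereocentre at a saturated ring carbon is drawn without a configuration in compound 1 and S in compound 3. Compounds 1 and 2 differ in the same way, (the fact that one of compounds 1 and 2 is drawn with a defined configuration and the other without, at the place where they differ). For the measured compounds named here, no measured step of this kind is available for comparison, so the step to compound 3 is expected to stay within the usual scatter, in either direction. Compound 3 is expected to give 12%, within 0% to 28%. The expected step is a number 3.8 percentage points lower from compound 1 to compound 3 (within the scatter).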

Compound 3, a percentage reported as inhibition, at one concentration (the size of the read-out at that concentration, not a potency): "active" (no number reported)
For compound 3 the study gives words and no number; there is nothing to compare the estimate with.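

Among the compounds shown here, compounds 2 and 3 are reported only as "active", without a number, and no step from compound 1 to either can be read. On these data alone, whether compound 2 and compound 3 differ from each other in this assay, or from compound 1 at 15.8%, stays open.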